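Swapping a hydroxy hydrogen for methyl across two amide cores

This account rests on a few compounds, and the source may have more. Where it says the series, first, only, none or still open, it means among the compounds named here.

Compound 1 `O=C(Nc1cccc(-n2cc(-c3ccncc3)c(-c3cc(O)cc(Cl)c3)n2)c1)Nc1ccc(Cl)c(Cl)c1` and compound 2 `COc1cc(Cl)cc(-c2nn(-c3cccc(NC(=O)Nc4ccc(Cl)c(Cl)c4)c3)cc2-c2ccncc2)c1` share one core, and they differ only by methyl in place of hydrogen on an oxygen on an aromatic ring. In a functional assay on CAKI-1 cells (Homo sapiens) for inhibition, read by sulforhodamine B assay, with a stated time of 48 h, tested at 10 uM (a lower number here means a stronger effect, a higher number a weaker effect of the compound at the concentration tested), compound 1 gives 5.31%, and compound 2 gives 7.49%; the step of a number 2.2 percentage points higher from compound 1 to compound 2 (within the scatter) is small, so the two numbers are best read as the same result.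

Compound 3 `O=C(Nc1cccc(-n2cc(-c3ccncc3)c(-c3cc(O)cc(Cl)c3)n2)c1)c1cc(C(F)(F)F)cc(C(F)(F)F)c1` carries a different core, and the difference between the two cores is not broken down here. In this assay compound 3 gives 58.5%, the highest of the three measured numbers; its steps to compound 1 and to compound 2 are both beyond the scatter, so among these three it has the weakest effect at the tested concentration.

Compound 4 `COc1cc(Cl)cc(-c2nn(-c3cccc(NC(=O)c4cc(C(F)(F)F)cc(C(F)(F)F)c4)c3)cc2-c2ccncc2)c1` has not yet been measured. Going by the values given here, it is made from compound 3 by methyl in place of hydrogen on an oxygen on an aromatic ring, the same change as the one from compound 1 to compound 2, at the same place. Because that earlier step a number 2.2 percentage points higher from compound 1 to compound 2 (within the scatter) stayed within the scatter, the change is expected to carry over with little movement onto the core of compound 3, and the step of a number 1.5 percentage points higher from compound 3 to compound 4 (within the scatter) is estimated to be small as well. Compound 4 is therefore expected to give about 60% in this assay, most likely between 45% and 78%, with a value close to that of compound 3 being the natural expectation.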

Compound 4, a percentage reported as activity, at one concentration (the size of the read-out at that concentration, not a potency): 68.6%
Compound 4: middle estimate off by 8.6 percentage points, on the low side, within the range that was stated.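

In this assay, placing methyl on the hydroxy oxygen of compound 3 gives a number 10.1 percentage points higher from compound 3 to compound 4 (beyond the scatter), a modest move toward a weaker effect at the tested concentration. Setting this beside the same change on the core of compound 1 shows that the two steps cannot be told apart, even though only the newer step passes the scatter on its own: the same change on two cores in this assay, a number 2.2 percentage points higher (within the scatter) from compound 1 to compound 2 and a number 10.1 percentage points higher (beyond the scatter) from compound 3 to compound 4, 7.9 percentage points apart, within the scatter of two such steps These two pairs therefore give no sign that the core alters what hydroxy to methoxy does, but two pairs are too few to show that the change would behave the same way on any further core, and they do not explain why the numbers moved.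

The compounds shown carry only hydroxy or methoxy at this place, so it remains open how a longer chain such as ethoxy, or an amine in place of the oxygen, would read in this assay on either core. As far as these compounds go, each value also comes from one concentration, so whether these compounds would show a stronger or weaker effect at other concentrations remains open as well.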